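A few compounds are considered here, and "the series" means these few. Any claim that something is new, unique, unknown or untested is made for them only; others in the source may bear on it.

Compound 1 `COc1ccc(-n2cc(COc3ccc(/C=C/C(=O)c4cc5c(cc4O)OC(C)(C)CC5)cc3)nn2)c([N+](=O)[O-])c1`: 99500 nM
Compound 3 `CC1(C)CCc2cc(C(=O)/C=C/c3ccc(OCc4cn(Cc5ccc([N+](=O)[O-])cc5)nn4)cc3)c(O)cc2O1`: 35800 nM
Compound 2 `CC1(C)CCc2c(ccc(C(=O)/C=C/c3ccc(OCc4cn(-c5ccc(Cl)cc5)nn4)cc3)c2O)O1`: "not active" (no number reported) (no number reported)

For the measured compounds named here, in a functional assay on A549 cells (Homo sapiens) for antiproliferative activity, read by MTT assay (on this read-out lower numbers stand for stronger inhibition and higher numbers for weaker inhibition), compound 1 gives 99500 nM and compound 3 gives 35800 nM; the one measured step is a 2.8-fold lower number from compound 1 to compound 3 (0.44 log units; beyond the scatter), where 4-nitrobenzyl replaces 4-methoxy-2-nitrophenyl on the aromatic nitrogen. Compound 2 gives "not active" (no number reported) in this assay, so no number places it against compounds 1 and 3. Compound 4 `CCCCCCCCn1cc(COc2ccc(/C=C/C(=O)c3ccc4c(c3O)CCC(C)(C)O4)cc2)nn1` differs from compound 2 by octyl in place of 4-chlorophenyl on an aromatic nitrogen. Going by the values given here, no measured step puts an octyl on that nitrogen, so the step from compound 2 to compound 4 has no direct precedent; the series as a whole sits in the weak range, and a limit rather than a number remains a real possibility. Compound 4 is estimated at 50000 nM, within 12000 nM to 200000 nM.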

Compound 4, half-maximal inhibitory concentration: "not active" (no number reported)
Nothing numeric was reported for compound 4; the estimate stays without a comparison.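

Compound 2 and compound 4 both lack a number in this assay, so no step can be read between them. Going by these compounds, how octyl compares with 4-chlorophenyl on that aromatic nitrogen stays open, and no measured evidence bears on the result.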